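A few compounds are considered here, and "the series" means these few. Any claim that something is new, unique, unknown or untested is made for them only; others in the source may bear on it.

The measured compounds:

Compound 1, `COC(=O)C1C2CCC3CCC1N(C/C2=C\c1ccc(-c2cccc(Cl)c2)cc1)C3`: 17.5 nM
Compound 2, `COC(=O)C1C2CCC3CCC1N(C/C2=C\c1ccc(-c2ccc(C#N)cc2)cc1)C3`: 32.4 nM

Both numbers come from an assay with Norepinephrine transporter (Rattus norvegicus) as the target; on this read-out higher numbers stand for weaker inhibition and lower numbers for stronger inhibition. Among the compounds with values here, compound 2 stands alongside compound 1 rather than apart from it: the step of a 1.9-fold higher number from compound 1 to compound 2 (0.27 log units; within the scatter) lies within the scatter, so the two cannot be told apart on this read-out, and there are no further measured compounds to place compound 2 against.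

Compound 3, `COC(=O)C1C2CCC3CCC1N(C/C2=C\c1ccc(-c2cccs2)cc1)C3`, has not yet been measured in this assay. It differs from compound 2 in one place: thiophen-2-yl in place of 4-cyanophenyl on an aromatic carbon. Within the data shown here, the only measured step that bears on this is the one from compound 1 to compound 2, which also swapped one ring for another at the same place of the shared core and stayed within the scatter. That single step gives no sign that this part of the molecule moves the number much, although with one example no pattern can be claimed.

The expectation for compound 3 is therefore a step of about a 1.3-fold lower number from compound 2 to compound 3 (0.11 log units; within the scatter), that is, nothing beyond the scatter. Compound 3 is estimated at 25 nM in this assay, with a range from 8 nM to 80 nM.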

Compound 3, inhibition constant: 19.8 nM
Estimate against measurement, compound 3: 1.3-fold (0.10 log units) above; measured number inside the range.
By their numbers in this assay, from the lowest: compounds 1, 3 and 2 (each within the scatter of the next).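

Thiophen-2-yl in place of 4-cyanophenyl gives a 1.6-fold lower number from compound 2 to compound 3 (0.21 log units; within the scatter) in this assay, and thiophen-2-yl in place of 3-chlorophenyl gives a 1.1-fold higher number from compound 1 to compound 3 (0.05 log units; within the scatter) on the same read-out. Within the data shown here, the earlier pair compared only two substituted six-membered rings of carbon, whereas this result shows that a five-membered aromatic ring with a sulfur atom, with 5 heavy atoms against the 8 of 4-cyanophenyl, also cannot be told apart from them at this place, on an aromatic carbon para to a large group. So in these three compounds, neither the ring size, the hetero atom nor the loss of the nitrile moves the number beyond the scatter, and no other measurement is available to explain this.

Going by these compounds, all three groups here are aromatic rings, so it remains open whether the number would also hold with something quite different at this place, such as an amine, a carboxylic acid or a longer chain. On these data alone, it is also open whether a plain phenyl ring, or thiophen-3-yl, would sit with these three compounds, since three examples fix only a small part of what this position can carry.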